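Swapping chloro for methyl in a cytotoxicity series

The source may report more compounds than this note shows. Statements on the series, on what has been measured and on what is new or still open speak of the compounds shown alone.

Two macrocyclic compounds sharing one core have been tested in an ADME assay on Huh-7 cells (Homo sapiens) for cytotoxicity, read by colorimetric assay; on this read-out lower numbers stand for higher toxicity in this test and higher numbers for lower toxicity in this test. Compound 1 `COc1ccc2c(O[C@H]3C[C@H]4C(=O)N(C)CCCC/C=C/[C@@H]5C[C@@]5(C(=O)NS(=O)(=O)C5(C)CC5)NC(=O)N4C3)cc(-c3nc(C(F)(F)F)cs3)nc2c1C` gives 75000 nM. Compound 2 `C#Cc1csc(-c2cc(O[C@H]3C[C@H]4C(=O)N(C)CCCC/C=C/[C@@H]5C[C@@]5(C(=O)NS(=O)(=O)C5(C)CC5)NC(=O)N4C3)c3ccc(OC)c(Cl)c3n2)n1` gives 17000 nM, the lowest of the two numbers, and the gap to compound 1 lies beyond the usual scatter, so compound 2 is the more toxic of the two on this read-out.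

Compound 3 `C#Cc1csc(-c2cc(O[C@H]3C[C@H]4C(=O)N(C)CCCC/C=C/[C@@H]5C[C@@]5(C(=O)NS(=O)(=O)C5(C)CC5)NC(=O)N4C3)c3ccc(OC)c(C)c3n2)n1` has not yet been measured in this assay. It differs from compound 2 in one place: methyl in place of chloro on an aromatic carbon. Among the measured compounds shown here, the only other compound with a methyl at that position, compound 1, gives 75000 nM in this assay, though it carries a different thiazole substituent, so no clean step for this exchange alone is available.

The step of a 1.8-fold higher number from compound 2 to compound 3 (0.25 log units; within the scatter) is therefore expected to be a modest rise toward lower toxicity, close to the edge of the scatter. Compound 3 is estimated at 30000 nM, within a range of 12000 nM to 80000 nM.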

Compound 3, half-maximal cytotoxic concentration: 75000 nM
Compound 3: middle estimate off by 2.5-fold (0.40 log units), on the low side, within the range that was stated.
By their numbers in this assay, from the lowest: compound 2; then compounds 1 and 3 (each within the scatter of the next).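

In this assay, methyl in place of chloro on the aromatic carbon ortho to a methoxy group gives a 4.4-fold higher number from compound 2 to compound 3 (0.64 log units; beyond the scatter), so this exchange can now be read on its own, and it moves the read-out toward lower toxicity in this test. Ethynyl in place of trifluoromethyl on an aromatic carbon, with the methyl kept, gives no change at the digits printed from compound 1 to compound 3 (within the scatter), which means that the earlier gap, where two changes were mixed, can in this small set be traced to the exchange of chloro for methyl and not to the other substituent. Nothing measured here accounts for why a single-atom exchange at this position shifts the read-out in this way.

From the compounds shown here alone, what remains open is whether other groups at this position, such as fluoro, an amine or a longer chain like ethyl, would read like methyl or like chloro. Going by these compounds, it is also open whether chloro would have the same effect alongside trifluoromethyl, since the step rests on one pair of compounds with ethynyl on the same core.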